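This account rests on a few compounds, and the source may have more. Where it says the series, first, only, none or still open, it means among the compounds named here.

In a functional assay on ECa-109 cells (Homo sapiens) for cytotoxicity, read by MTT assay, with a stated time of 72 h (on this read-out higher numbers stand for weaker inhibition and lower numbers for stronger inhibition), three compounds sharing one core have been measured, and they differ only in the aromatic group on a double-bonded chain carbon bound to a double-bonded ring carbon. Compound 1 `COc1cccc(C=C2C(=O)N(c3ccc(Cl)cc3)N(c3ccc(Cl)cc3)C2=O)c1` gives 29000 nM, compound 2 `COc1cccc(C=C2C(=O)N(c3ccc(Cl)cc3)N(c3ccc(Cl)cc3)C2=O)c1OC` gives 6800 nM, and compound 3 `O=C1C(=Cc2ccc(Cl)cc2Cl)C(=O)N(c2ccc(Cl)cc2)N1c1ccc(Cl)cc1` gives 60200 nM. Compound 3 therefore has the highest number of the three, which means the weakest inhibition in this set. Compound 4 `O=C1C(=Cc2c[nH]c3ccccc23)C(=O)N(c2ccc(Cl)cc2)N1c1ccc(Cl)cc1` has 1H-indol-3-yl in place of the 2,4-dichlorophenyl of compound 3: 1H-indol-3-yl in place of 2,4-dichlorophenyl on a double-bonded chain carbon bound to a double-bonded ring carbon.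

Going by the values given here, no measured compound carries 1H-indol-3-yl, so there is no direct precedent for this swap. The nearest evidence comes from changes at the same place. Going to the 2,4-dichlorophenyl group gives a 2.1-fold higher number from compound 1 to compound 3 (0.32 log units; beyond the scatter) and an 8.9-fold higher number from compound 2 to compound 3 (0.95 log units; beyond the scatter), and adding one methoxy gives a 4.3-fold lower number from compound 1 to compound 2 (0.63 log units; beyond the scatter). All three steps are modest but beyond the scatter. Among the compounds with values here, since both other groups sit lower than compound 3, a modest fall in this assay is the likeliest outcome, though this rests on only two comparisons. The expected step is a 3.0-fold lower number from compound 3 to compound 4 (0.48 log units; beyond the scatter). The estimated value for compound 4 is 20000 nM, with an expected range from 6000 nM to 60000 nM.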

Compound 4, half-maximal inhibitory concentration: 23400 nM
Estimate against measurement, compound 4: 1.2-fold (0.07 log units) below, and the stated range covers the measured number.
By their numbers in this assay, from the lowest: compound 2; then compounds 4 and 1 (each within the scatter of the next); then compound 3.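

In this assay, the place on a double-bonded chain carbon bound to a double-bonded ring carbon proves able to hold more than a substituted phenyl: swapping 2,4-dichlorophenyl for the two-ring 1H-indol-3-yl gives a 2.6-fold lower number from compound 3 to compound 4 (0.41 log units; beyond the scatter), a modest step towards stronger inhibition. The new group, which counts one hydrogen-bond donor, still brings no separation from a single methoxy-bearing phenyl, with a 1.2-fold lower number from compound 1 to compound 4 (0.09 log units; within the scatter), and it stays behind the dimethoxy group, with a 3.4-fold higher number from compound 2 to compound 4 (0.54 log units; beyond the scatter), so 2,3-dimethoxyphenyl keeps the lowest number of the four. Nothing measured here accounts for these differences.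

The compounds shown leave open whether the hydrogen on the nitrogen of 1H-indol-3-yl matters at all, a question that a 1-methylindol-3-yl group would test directly. As far as these compounds go, it also remains open how other kinds of group would behave at this place, such as a phenyl ring carrying an amine or a carboxylic acid, and whether the order seen here would hold if the rest of the shared core were changed.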